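Compound 3 to compound 4: benzylamino to methylamino

The source may report more compounds than this note shows. Statements on the series, on what has been measured and on what is new or still open speak of the compounds shown alone.

In a physicochemical assay for solubility, read by nephelometry (a lower number here means a less soluble compound, a higher number a more soluble compound), compound 3 (`CC1(C)C(=O)N(c2ccc(SC(F)(F)F)cc2)C(=O)N1Cc1ccnc(NCc2ccccc2)c1`) gives < 0.026 ug/mL, which is a limit and not a number. Compound 4 (`CNc1cc(CN2C(=O)N(c3ccc(SC(F)(F)F)cc3)C(=O)C2(C)C)ccn1`) has not yet been measured. It differs by hydrogen in place of phenyl on a saturated chain carbon bound to a nitrogen on an aromatic ring, so that benzylamino becomes methylamino.

Two further compounds frame this change. Compound 1 (`CC1(C)C(=O)N(c2ccc(SC(F)(F)F)cc2)C(=O)N1Cc1ccnc(N2CCCCC2)c1`), with piperidin-1-yl instead of benzylamino, gives < 0.024 ug/mL, again a limit. Compound 2 (`CC1(C)C(=O)N(c2ccc(SC(F)(F)F)cc2)C(=O)N1Cc1ccnc(C(=O)O)c1`), with carboxy there, gives 0.142 ug/mL, a true number. The data show a step that the two limits leave unreadable from compound 1 to compound 3, so those two compounds cannot be ordered. The readable steps both involve compound 2: an at least 5.9-fold higher number from compound 1 to compound 2 (0.77 log units; beyond the scatter) and an at least 5.4-fold lower number from compound 2 to compound 3 (0.73 log units; beyond the scatter), each beyond the scatter.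

Going by the values given here, no measured step makes the change from benzylamino to methylamino itself. Compound 4 carries no carboxy, so a step as large as an at least 5.4-fold lower number from compound 2 to compound 3 (0.73 log units; beyond the scatter) is not expected in reverse. A small upward move in this assay is expected, and the estimated step is an at least 1.5-fold higher number from compound 3 to compound 4 (0.18 log units; that floor lies within the scatter). Compound 4 is estimated at 0.04 ug/mL, with an expected range of 0.015 ug/mL to 0.2 ug/mL.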

Compound 4, solubility: 0.075 ug/mL
Beside the measured number, compound 4's estimate is 1.9-fold (0.27 log units) below it, and the stated range covers the measured number.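

In this assay, going by these compounds alone, hydrogen in place of phenyl on a saturated chain carbon bound to a nitrogen on an aromatic ring gives the first readable step among the compounds with nitrogen groups at this position: an at least 2.8-fold higher number from compound 3 to compound 4 (0.46 log units; beyond the scatter). Methylamino also separates from piperidin-1-yl, with an at least 3.1-fold higher number from compound 1 to compound 4 (0.49 log units; beyond the scatter), so compound 4 is the first of these nitrogen-substituted compounds to give a true number rather than a limit. Within the data shown here, the comparison with the carboxy compound gives a 1.9-fold lower number from compound 2 to compound 4 (0.28 log units; within the scatter), so in this assay methylamino and carboxy on this aromatic carbon cannot be told apart, and carboxy is no longer the only group here with a readable value.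

Compounds 1 and 3 both stand at limits, so the step between them cannot be read, and the two steps up to compound 4 give only floors, leaving their true sizes unknown. The compounds shown leave open whether an unsubstituted amino group, ethylamino or dimethylamino would stay with methylamino in this assay or fall to the limits seen for benzylamino and piperidin-1-yl.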